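Swapping the benzyl arm for an isopropyl-bearing aniline

This account rests on a few compounds, and the source may have more. Where it says the series, first, only, none or still open, it means among the compounds named here.

Two compounds of this series carry a chloropyrimidine core joined to an aminopyridine bearing a piperazine, with the variable arm on the remaining ring nitrogen. Compound 1 `Cc1ccccc1Nc1nc(Nc2ccc(N3CCNCC3)cn2)ncc1Cl` in a functional assay on Jurkat cells (Homo sapiens) for inhibition, read by CCK-8 assay, with a stated time of 48 h (a higher number here means a weaker inhibitor of growth, a lower number a stronger inhibitor of growth), gives 7870 nM. Compound 2 `COc1ccc(CNc2nc(Nc3ccc(N4CCN(C)CC4)cn3)ncc2Cl)cc1` in this assay gives 12900 nM. Compound 2 has the highest number among the two, yet the gap to compound 1 lies within the usual scatter of such measurements, so the two compounds are best regarded as standing together.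

Compound 3 `CC(C)c1ccccc1Nc1nc(Nc2ccc(N3CCN(C)CC3)cn2)ncc1Cl` has not been measured. It differs from compound 2 in one place: 2-isopropylphenyl in place of 4-methoxybenzyl on a nitrogen on an aromatic ring. Going by the values given here, no pair of measured compounds separated by exactly this change exists, so the size of the step can only be guessed from the two numbers at hand. Since compound 1 and compound 2 sit together, no strong movement is expected; a modest shift toward a lower number in this assay seems plausible for compound 3, and the estimated step is a 2.0-fold lower number from compound 2 to compound 3 (0.30 log units; within the scatter). Compound 3 is thus expected to give roughly 6500 nM in this assay, within a range of 2000 nM to 20000 nM.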

Compound 3, concentration for 50% growth inhibition: 5140 nM
Estimate against measurement, compound 3: 1.3-fold (0.10 log units) above, and the stated range covers the measured number.
By their numbers in this assay, from the lowest: compounds 3, 1 and 2 (each within the scatter of the next, the first and the last beyond it).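

Going by these compounds alone, the exchange of 4-methoxybenzyl for 2-isopropylphenyl on a nitrogen on an aromatic ring gives a 2.5-fold lower number from compound 2 to compound 3 (0.40 log units; beyond the scatter) in this assay, and this is the first step that can be read as a change at a single place. The earlier compounds shown here could not show whether this arm matters, since they differ in more than one place and stand within the scatter of each other, whereas this pair shows that the number responds to the group on this nitrogen, even though the step is modest and the two groups carry the same number of heavy atoms, with the oxygen and its hydrogen-bond acceptor leaving. Nothing at hand says what lies behind the step.

The change bundles several edits into one, namely the loss of the methoxy group, the loss of the methylene link to the ring and the arrival of the isopropyl group, and the compounds shown do not separate them. On these data alone, how a plain phenyl, a plain benzyl or a cyclohexyl group on the same nitrogen would stand in this assay remains open.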